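Cyano for Methyl: Compound 4 Follows Compound 2

The source may hold more compounds than are shown below. What is called first, only, known or untested is meant among the compounds shown, and "the series" means these compounds.

Measured so far in a functional assay on NIH3T3 cells (Mus musculus); a lower number here means that less compound is needed, a higher number that more compound is needed for the effect:
compound 1, `COC(=O)[C@H](CCSC)NC(=O)c1ccc(CNCc2cncn2Cc2ccc(C#N)cc2)cc1-c1ccccc1C`, gives > 10 uM.
compound 2, `CSCC[C@H](NC(=O)c1ccc(NCc2cncn2Cc2ccccc2C)cc1-c1ccccc1)C(=O)O`, gives > 10 uM.
compound 3, `COC(=O)[C@H](CCSC)NC(=O)c1ccc(NCc2cncn2Cc2ccc(Cl)cc2)cc1-c1ccccc1`, gives > 10 uM.

Each of these three values is a limit of this assay and not a number; (the limit of > 10 uM in this assay, at which 3 of the 3 values shown sit). Compound 2 therefore stands at the limit, and compounds 1 and 3 stand at the same limit, so none of the three can be placed above or below another on the numbers shown. Within the data shown here, no pair among them differs in one place only, so no measured step is known.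

The next compound, compound 4, `CSCC[C@H](NC(=O)c1ccc(NCc2cncn2Cc2ccccc2C#N)cc1-c1ccccc1)C(=O)O`, has yet to be measured in this assay. It differs from compound 2 in one place: cyano in place of methyl on an aromatic carbon. Among the measured compounds shown here, with compound 2 at a limit and no comparable measured step at hand, there is no basis for expecting a change beyond the usual scatter in either direction; the most likely outcome is that compound 4 also comes back as a limit. Compound 4 is accordingly expected to give about 15 uM in this assay, within 5 uM to 50 uM. This estimate corresponds to an expected step that the limit leaves unreadable from compound 2 to compound 4, which lies within the scatter.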

Compound 4, concentration for half-maximal effect: > 10 uM
Compound 4: no number, only a limit; the forecaster's own chance of this, stated with the estimate: 80%; the middle value is on the limit's open side.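

In this assay compound 4 gives > 10 uM, which is a limit of the assay and not a number. No step can be read between compound 2 and compound 4, because both sit at the same limit: the limit of > 10 uM in this assay, at which 4 of the 4 values shown sit.

The compounds shown leave open whether cyano in place of methyl changes anything here, and what concentration any of the four would need for the effect.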